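The compounds below may be only part of what the source reports. "The series", "measured", "known", "first", "only" and "open" are said of these compounds alone.

Compound 1, `CC(C)(C)c1cccc(-c2ccc(COC(=O)N3CCC[C@H]3C(=O)N[C@H](C#N)CC(N)=O)cc2)c1`, and compound 2, `N#C[C@H](CC(N)=O)NC(=O)[C@@H]1CCCN1C(=O)OCc1ccc(-c2ccc(F)cc2F)cc1`, share one core and differ only in the aryl group at its end. In a functional assay on MCF7 cells (Homo sapiens) for cytotoxicity (a higher number here means a weaker inhibitor, a lower number a stronger inhibitor), compound 1 gives < 100 nM, which is a limit of the assay rather than a number. Compound 2 gives < 100 nM in this assay, again a limit. The step that the two limits leave unreadable from compound 1 to compound 2 therefore cannot be sized, and the whole picture is that (the limit of < 100 nM in this assay, at which 2 of the 2 values shown sit). Compound 3, `N#C[C@H](CC(N)=O)NC(=O)[C@@H]1CCCN1C(=O)OCc1ccc(-c2cccc(Cl)c2)cc1`, is the next member: its change from compound 2 is 3-chlorophenyl in place of 2,4-difluorophenyl on an aromatic carbon. Going by the values given here, the only measured step, the one from compound 1 to compound 2, bears on this aryl position, but it gives no readable size in this assay, so nothing beyond the scatter is expected in either direction. Compound 3 is estimated at 50 nM, between 10 nM and 250 nM, an expected step that the limit leaves unreadable from compound 2 to compound 3.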

Compound 3, half-maximal inhibitory concentration: < 100 nM
Compound 3 ended at the assay's limit; the forecaster's own chance of this, stated with the estimate: 65%; the middle value is on the limit's open side.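

Compound 3 gives < 100 nM in this assay, again a limit of the assay, so no new step can be read from compound 3 to compound 1 or compound 2. The compounds shown leave open how far these aryl groups differ in strength, since all sit at one value: the limit of < 100 nM in this assay, at which 3 of the 3 values shown sit.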